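Cyanoguanidine aryl exchange in a chromanol series

The compounds below may be only part of what the source reports. "The series", "measured", "known", "first", "only" and "open" are said of these compounds alone.

Measured so far in a functional assay (aorta) with Rattus norvegicus as the target; a lower number here means a stronger inhibitor, a higher number a weaker inhibitor:
compound 1 `CC1(C)Oc2ccc(C#N)cc2[C@@H](NC(=O)NCc2ccccc2)[C@@H]1O` — 5600 nM
compound 2 `CC1(C)Oc2ccc(C#N)cc2[C@@H](n2c(O)nc3ccccc32)[C@@H]1O` — 41000 nM
compound 3 `CC1(C)Oc2ccc(C#N)cc2[C@@H](/N=C(\NC#N)Nc2cccc(Cl)c2)[C@@H]1O` — 600 nM

Compound 3 holds the lowest number of the three. Compound 1 sits at a higher number, beyond the scatter, and compound 2 higher still, also beyond the scatter. Within the data shown here, no pair of measured compounds differs in only one place, so the three values stand on their own and no measured step can be read from them.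

Compound 4 `CSc1ccc(N/C(=N/[C@@H]2c3cc(C#N)ccc3OC(C)(C)[C@H]2O)NC#N)cc1` differs from compound 3 in one place: 4-(methylsulfanyl)phenyl in place of 3-chlorophenyl on an amine nitrogen. The arylamino part of the cyanoguanidine is exchanged; the rest of compound 3 is kept. Among the measured compounds shown here, nothing among the measured compounds shows what such an exchange at this position does, since compounds 1 and 2 alter a different part of the molecule.

The expected step from compound 3 to compound 4 is a 2.0-fold higher number from compound 3 to compound 4 (0.30 log units; within the scatter), a modest move toward a higher number, close to the edge of the scatter. Compound 4 is estimated at 1200 nM, with a range from 300 nM to 5000 nM.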

Compound 4, half-maximal inhibitory concentration: 6300 nM
The estimate for compound 4 lay 5.3-fold (0.72 log units) below the measured number; measured number above the stated range.
By their numbers in this assay, from the lowest: compound 3; then compounds 1 and 4 (each within the scatter of the next); then compound 2.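

The arylamino part of the cyanoguanidine is not a silent position in this assay: 4-(methylsulfanyl)phenyl in place of 3-chlorophenyl on this amine nitrogen gives an 11-fold higher number from compound 3 to compound 4 (1.02 log units; beyond the scatter). Among these compounds, this is the only single-place step so far, and it shows that the number responds strongly to the aryl group alone, with the rest of compound 3 kept. No available data bear on the reason for this step.

The substituent and its printed ring position change together here, so the step cannot be divided between the two. On these data alone, whether 4-chlorophenyl, 3-(methylsulfanyl)phenyl or unsubstituted phenyl would stay close to compound 3 or to compound 4 remains open, as does the effect of a methoxy group or a pyridyl ring at this nitrogen.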